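A Chloromethyl Swap at the Cytotoxicity Limit

A few compounds are considered here, and "the series" means these few. Any claim that something is new, unique, unknown or untested is made for them only; others in the source may bear on it.

In an ADME assay on H9c2 cells (Rattus norvegicus) for cytotoxicity, read by resazurin assay, with a stated time of 72 h (on this read-out higher numbers stand for lower toxicity in this test and lower numbers for higher toxicity in this test), compound 1 (`C/C(=N\Nc1nc(CCl)cs1)c1ccc(Cl)c(Cl)c1`) gives > 50000 nM as its result, which is a limit of the assay and not a number. Compound 1 therefore offers no exact starting value. In compound 4 (`C/C(=N\Nc1nc(-c2ccc(C)cc2)cs1)c1ccc(Cl)c(Cl)c1`) 4-methylphenyl stands in place of chloromethyl on an aromatic carbon of the shared core (4-methylphenyl in place of chloromethyl on an aromatic carbon). Within the data shown here, no measured pair of compounds shows the size of this change directly, so the nearest guidance comes from two relatives. Compound 2 (`C/C(=N\Nc1nc(-c2ccccc2)c(C)s1)c1ccc(Cl)c(Cl)c1`) carries a six-membered aromatic ring of carbon only and gives > 50000 nM as a limit too. Compound 3 (`C/C(=N\N=c1\scc(-c2ccccc2)n1-c1ccccc1)c1ccc(Cl)c(Cl)c1`) also carries such a ring and gives > 50000 nM as a limit as well. On that basis, no step beyond the scatter is expected in this assay and the estimated step is a number no higher from compound 1 to compound 4 (the limit leaves the size open) in size. Compound 4 is expected at 50000 nM within a range of 25000 nM to 100000 nM and quite possibly as a limit again.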

Compound 4, half-maximal cytotoxic concentration: > 50000 nM
Compound 4: a limit, no number; the forecaster's own chance of this, stated with the estimate: 80%; the middle value lies on the limit itself.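

Compound 1 and compound 4 each give a limit of the assay and not a number, so no step can be read between them: the limit of > 50000 nM in this assay, at which 4 of the 4 values shown sit.

The compounds shown leave open whether 4-methylphenyl in place of chloromethyl changes the result in this assay at all.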